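Removing the methylene linker before the pyridinyloxy group

The source may hold more compounds than are shown below. What is called first, only, known or untested is meant among the compounds shown, and "the series" means these compounds.

The series shares the core of compound 1 `CSCc1ccc(Nc2ncc(Cc3c(F)cccc3F)o2)cc1`. Compound 2 `O=c1ncccn1SCCc1ccc(Nc2ncc(Cc3c(F)cccc3F)o2)cc1` and compound 3 `Fc1cccc(F)c1Cc1cnc(Nc2ccc(COc3ccncc3)cc2)o1` vary the group on the saturated chain carbon bound to an aromatic carbon. In an ADME assay on MT2 cells (Homo sapiens) for cytotoxicity, read by MTT assay (a lower number here means that less compound is tolerated, a higher number that more compound is tolerated), compound 1 gives > 100000 nM, a limit of the assay and not a number. In this assay compound 2 gives > 100000 nM, again only a limit. In this assay compound 3 gives > 100000 nM, also a limit. The step that the two limits leave unreadable from compound 1 to compound 2, the step that the two limits leave unreadable from compound 1 to compound 3 and the step that the two limits leave unreadable from compound 2 to compound 3 carry no readable size, because of the limit of > 100000 nM in this assay, at which 3 of the 3 values shown sit. Compound 3 thus stands where every measured value stands, at the limit, with nothing to set it apart from compound 1 or compound 2.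

Compound 4 `Fc1cccc(F)c1Cc1cnc(Nc2ccc(Oc3ccncc3)cc2)o1` differs from compound 3 in one place: (pyridin-4-yl)oxy in place of ((pyridin-4-yl)oxy)methyl on an aromatic carbon. For the measured compounds named here, no measured step bears directly on this change, and the three measured steps all stayed unreadable, so no direction can be drawn from them. The expectation is that the step that the limit leaves unreadable from compound 3 to compound 4 stays within the scatter and that compound 4 again reaches the limit. Compound 4 is estimated at 150000 nM in this assay, with a range from 60000 nM to 400000 nM.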

Compound 4, half-maximal cytotoxic concentration: 21000 nM
For compound 4 the middle estimate is 7.1-fold (0.85 log units) above the measured one; measured number below the stated range.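

In this assay, for the compounds shown here, the change to (pyridin-4-yl)oxy from ((pyridin-4-yl)oxy)methyl, on an aromatic carbon para to a large group, gives the first step with a readable lower bound: an at least 4.7-fold lower number from compound 3 to compound 4 (0.67 log units; beyond the scatter). The same compound also separates from the other two members of the series, with an at least 4.7-fold lower number from compound 2 to compound 4 (0.67 log units; beyond the scatter) and with an at least 4.7-fold lower number from compound 1 to compound 4 (0.67 log units; beyond the scatter), so this position can move the read-out, whereas the groups carried on the saturated chain carbon gave no such separation. All three new steps are lower bounds, their full size stays unknown, and the steps among compound 1, compound 2 and compound 3 still cannot be read: the limit of > 100000 nM in this assay, at which 3 of the 4 values shown sit.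

With (pyridin-4-yl)oxy as the only group shown directly on this aromatic carbon, it stays open whether an amine or a carboxylic acid there would lower the number in the same way. On these data alone, it also stays open whether a longer chain before the pyridin-4-yl ring would keep these compounds at the limit, and whether a plain phenoxy group would follow compound 4.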